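The compounds below may be only part of what the source reports. "The series", "measured", "known", "first", "only" and "open" are said of these compounds alone.

Working notes on the coumarin-type series, read in an ADME assay on A549 cells (Homo sapiens) for cytotoxicity, read by CellTiter-Glo; on this read-out higher numbers stand for lower toxicity in this test and lower numbers for higher toxicity in this test.

Compound 1, `Cc1c(Cc2ccccc2)c(=O)oc2cc(OCC(O)CNc3ccc(Br)cc3)ccc12`, reaches only the assay limit of > 100000 nM and gives no number. Compound 2, `Cc1noc(C)c1-c1ccc(Cc2c(C)c3ccc(OCC(O)CN4CCC(C(N)=O)CC4)cc3oc2=O)cc1`, gives 36900 nM in this assay. Among the compounds with values here, compound 2 is therefore the only compound with a measured number here; the other value is a limit, which is the limit of > 100000 nM in this assay, at which 1 of the 2 values shown sits. Within the data shown here, no step between measured compounds is available, so no size of change has been seen in this assay.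

Compound 3, `Cc1c(Cc2ccc(-c3ccc(C#N)c(F)c3)cc2)c(=O)oc2cc(OCC(O)CN3CCC(C(N)=O)CC3)ccc12`, is not yet measured. It differs from compound 2 in one place: 4-cyano-3-fluorophenyl in place of 3,5-dimethyl-1,2-oxazol-4-yl on an aromatic carbon. Among the measured compounds shown here, with no measured step to lean on, the change is expected to move the read-out by no more than the usual scatter, so the step from compound 2 to compound 3 is estimated as a 1.2-fold lower number from compound 2 to compound 3 (0.09 log units; within the scatter). For compound 3 the estimate in this assay is 30000 nM, expected to lie between 10000 nM and 90000 nM.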

Compound 3, half-maximal cytotoxic concentration: 29100 nM
Compound 3: the middle estimate sits 1.0-fold (0.01 log units) above what was measured; the measured number falls inside the stated range.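

Within the data shown here, the step of a 1.3-fold lower number from compound 2 to compound 3 (0.10 log units; within the scatter) is the first size of change read in this assay, and it sits on an aromatic carbon of a six-membered aromatic ring of carbon only, para to a large group. At this place, 4-cyano-3-fluorophenyl, a six-membered aromatic ring of carbon only, and 3,5-dimethyl-1,2-oxazol-4-yl, a five-membered aromatic ring with 2 hetero atoms, cannot be told apart in this test. Nothing measured here bears on why the read-out holds across this change.

Still open, going by these compounds, is whether a different kind of group at this place, such as a carboxylic acid or a primary amine, would give a step beyond the scatter. The nitrile and the fluorine of 4-cyano-3-fluorophenyl also enter together here and are not read apart.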